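This account rests on a few compounds, and the source may have more. Where it says the series, first, only, none or still open, it means among the compounds named here.

Compound 1 `O=C(O)c1cnc(-c2ccccc2)[nH]c1=O` gives 50 mg/kg in a functional assay on the whole organism (strain Sprague-Dawley) for inhibition, with Rattus norvegicus as the target, with a stated time of 10 min; a higher number here means that more compound is needed for the effect, a lower number that less compound is needed. Compound 2 `COc1cccc(-c2ncc(C(=O)O)c(=O)[nH]2)c1` gives 10 mg/kg in this assay; the change between them is methoxy in place of hydrogen on an aromatic carbon, and the step is a 5.0-fold lower number from compound 1 to compound 2 (0.70 log units; beyond the scatter). Compound 3 `CCOC(=O)c1cnc(-c2ccc(OC)cc2)[nH]c1=O` gives 30 mg/kg in this assay; the difference between its core and that of compound 1 is not broken down here. Compound 4 `CCOC(=O)c1cnc(-c2ccc(OC)cc2OC)[nH]c1=O` has not yet been measured and differs from compound 3 by methoxy in place of hydrogen on an aromatic carbon. This is the same kind of change as that from compound 1 to compound 2, but the place is not the same: in compound 4 the methoxy enters ortho to a large group and meta to a methoxy group, whereas in compound 2 it enters meta to a large group. Because the earlier change produced a 5.0-fold lower number from compound 1 to compound 2 (0.70 log units; beyond the scatter), compound 4 is expected to show a step of a 2.5-fold lower number from compound 3 to compound 4 (0.40 log units; beyond the scatter) in this assay. The place differs, and the expected step is set smaller than the earlier one. Compound 4 is therefore estimated at 12 mg/kg, with a likely range from 4 mg/kg to 35 mg/kg.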

Compound 4, dose for 50% inhibition: 5 mg/kg
For compound 4 the middle estimate is 2.4-fold (0.38 log units) above the measured one; the range from low to high includes it.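

In this assay methoxy in place of hydrogen on an aromatic carbon gives a 6.0-fold lower number from compound 3 to compound 4 (0.78 log units; beyond the scatter) and, set beside the earlier step on the other core, the change carries over with a similar size: the same change on two cores in this assay, a 5.0-fold lower number (0.70 log units; beyond the scatter) from compound 1 to compound 2 and a 6.0-fold lower number (0.78 log units; beyond the scatter) from compound 3 to compound 4, 1.2-fold (0.08 log units) apart, within the scatter of two such steps. This rests on a single pair of cores, so it does not show that the step would hold on any further core. The methoxy also enters at a different place in compound 4, ortho to a large group and meta to a methoxy group, so the agreement does not separate the role of the core from that of the place.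

Going by these compounds, it remains open whether an amine or a longer chain in place of the methoxy would give a similar step. On these data alone, it is also open whether a methoxy at this same place on the core of compound 1 would match it.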